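Removing the chloro from compound 2: what to expect

The source may hold more compounds than are shown below. What is called first, only, known or untested is meant among the compounds shown, and "the series" means these compounds.

The work concerns antiproliferative activity in a functional assay on K562 cells (Homo sapiens) for antiproliferative activity, read by sulforhodamine B assay, with a stated time of 48 h; a higher number here means that more compound is tolerated, a lower number that less compound is tolerated. Compound 1 `COc1ccc(OC)c(/C=C/c2nnc(Nc3ccc(Cl)cc3)o2)c1` joins the shared dimethoxyphenyl-vinyl part to its chlorophenyl part through a different linker. In this assay compound 1 reaches only a limit of the assay, > 100000 nM. Compound 2 `COc1ccc(OC)c(/C=C/C(=O)N/N=C/c2ccc(Cl)cc2)c1` is the second measured member. In this assay compound 2 likewise reaches only a limit, > 100000 nM. Compound 2 therefore stands at the limit of > 100000 nM in this assay, at which 2 of the 2 values shown sit; no number below that limit is known for either compound, and the two cannot be told apart on what has been measured.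

Compound 3 `COc1ccc(OC)c(/C=C/C(=O)N/N=C/c2ccccc2)c1` differs from compound 2 in one place: hydrogen in place of chloro on an aromatic carbon. Among the measured compounds shown here, no step between measured compounds exists, so the size of this change can only be anticipated. Since compound 2 sits at the limit > 100000 nM in this assay, the change is expected to produce no step beyond the scatter, and compound 3 is expected to remain at or beyond that limit. The step from compound 2 to compound 3 is expected to be a step that the limit leaves unreadable from compound 2 to compound 3. Compound 3 is estimated at 200000 nM, within a range from 60000 nM to 600000 nM.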

Compound 3, concentration lethal to 50% of the cells: > 100000 nM
Compound 3: a limit, no number; the forecaster's own chance of this, stated with the estimate: 85%; the middle value is on the limit's open side.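

In this assay compound 3 gives > 100000 nM, a limit of the assay and not a number. Compound 2 also stands only at a limit, so no step can be read between compound 2 and compound 3. The compounds shown leave open what number compound 1, compound 2 or compound 3 would take, and so what the change from 4-chlorophenyl to phenyl does: the limit of > 100000 nM in this assay, at which 3 of the 3 values shown sit.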